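This account rests on a few compounds, and the source may have more. Where it says the series, first, only, none or still open, it means among the compounds named here.

Among the measured compounds shown here, in an ADME assay on microsomes from liver (Mus musculus) for metabolic stability, with a stated time of 10 min (a lower number here means that less of the compound is left, a higher number that more of the compound is left), two compounds with a shared core have numbers so far. Compound 1 `C[C@]1(C(=O)N2CC[C@](c3ccc(C(F)(C(F)(F)F)C(F)(F)F)cc3)(S(=O)(=O)c3ccc(F)cc3)C2)CC[C@H](C(=O)O)CC1` stands at 95% and compound 2 `O=C(O)C12CCC(C(=O)N3CC[C@](c4ccc(C(F)(C(F)(F)F)C(F)(F)F)cc4)(S(=O)(=O)c4ccc(F)cc4)C3)(CC1)CC2` stands at 73% as the lower of the two. Compound 3 `O=C([C@H]1CC[C@H](CO)CC1)N1CC[C@](c2ccc(C(F)(C(F)(F)F)C(F)(F)F)cc2)(S(=O)(=O)c2ccc(F)cc2)C1` is still unmeasured. Its change from compound 2 is a group of 8 heavy atoms (7 carbon, 1 oxygen; one six-membered non-aromatic ring of carbon only) in place of a group of 11 heavy atoms (9 carbon, 2 oxygen; 2 six-membered non-aromatic rings of carbon only), on a carbonyl carbon and 4-(hydroxymethyl)cyclohexyl is the group that enters, with no net charge. For the measured compounds named here, the one measured step that bears on this is a number 22 percentage points lower from compound 1 to compound 2 (beyond the scatter) at the same carbonyl carbon, but it swapped a different pair of groups and so sets only a rough size. Going by the values given here, no measured compound carries 4-(hydroxymethyl)cyclohexyl, so a smaller step in the same downward direction is expected, possibly inside the scatter. The expected change is a number 8 percentage points lower from compound 2 to compound 3 (within the scatter) by this estimate. For compound 3 the estimate in this assay is 65% with an expected range of 40% to 88% for the coming measurement.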

Compound 3, percent of the compound remaining: 63%
For compound 3 the middle estimate is 2 percentage points above the measured one, within the range that was stated.
By their numbers in this assay, from the lowest: compounds 3 and 2 (each within the scatter of the next); then compound 1.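

In this assay the step to 4-(hydroxymethyl)cyclohexyl reads a number 10 percentage points lower from compound 2 to compound 3 (within the scatter) so compound 3 and compound 2 cannot be told apart here, even though the group that enters has one ring fewer. Set against 4-carboxy-1-methylcyclohexyl on the same carbonyl carbon, the same group gives a number 32 percentage points lower from compound 1 to compound 3 (beyond the scatter) and this is the largest step at this position so far, leaving compound 1 clear of both other compounds. Nothing at hand explains why these numbers differ.

On these data alone, it remains open how a plain 4-carboxycyclohexyl group without the methyl would read in this assay and so whether the methyl or the carboxylic acid of compound 1 goes with its number. As far as these compounds go, an amine or a longer chain in place of the hydroxymethyl on this ring is equally open.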